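Naphthyl carbinol amides: chloro to nitro on the aryl ring

The source may hold more compounds than are shown below. What is called first, only, known or untested is meant among the compounds shown, and "the series" means these compounds.

Compound 1 `CCC(=O)Nc1c(C(O)(C(F)(F)F)C(F)(F)F)ccc2ccccc12` gives 15 nM in an assay on LtK cells with ATP-sensitive inward rectifier potassium channel 11 (Homo sapiens) as the target; a lower number here means that less compound is needed, a higher number that more compound is needed for the effect. For the measured compounds named here, compound 2 `O=C(Nc1c(C(O)(C(F)(F)F)C(F)(F)F)ccc2ccccc12)c1cccc(Cl)c1` gives 98 nM in this assay, the higher of the two numbers measured so far; the only step known is a 6.5-fold higher number from compound 1 to compound 2 (0.82 log units; beyond the scatter). Compound 3 `O=C(Nc1c(C(O)(C(F)(F)F)C(F)(F)F)ccc2ccccc12)c1cccc([N+](=O)[O-])c1` differs from compound 2 by nitro in place of chloro on an aromatic carbon, sitting on an aromatic carbon of a six-membered aromatic ring of carbon only. Going by the values given here, no measured step exchanges one substituent on that aromatic ring for another: the single step, a 6.5-fold higher number from compound 1 to compound 2 (0.82 log units; beyond the scatter), swaps ethyl for 3-chlorophenyl as a whole and says nothing about chloro against nitro. The step expected here, a 1.2-fold higher number from compound 2 to compound 3 (0.09 log units; within the scatter), is therefore taken as lying within the scatter of this assay, with no direction to read from the numbers. Compound 3 is estimated at 120 nM, with a range of 40 nM to 400 nM.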

Compound 3, half-maximal effective concentration: 117 nM
Estimate against measurement, compound 3: 1.0-fold (0.01 log units) above; the measured number falls inside the stated range.
By their numbers in this assay, from the lowest: compound 1; then compounds 2 and 3 (each within the scatter of the next).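

At the position meta to a large group, the exchange of chloro for nitro leaves the read-out in this assay unmoved: a 1.2-fold higher number from compound 2 to compound 3 (0.08 log units; within the scatter). A group of 3 heavy atoms with 2 hydrogen-bond acceptors thus reads the same here as a single chlorine. The gap to the ethyl amide also holds with the second aryl group, a 7.8-fold higher number from compound 1 to compound 3 (0.89 log units; beyond the scatter), so it does not depend on which of these two substituents the ring carries. No measurement at hand bears on the reason for either step.

Going by these compounds, whether this position is indifferent to substituents in general stays open, since an amine or a carboxylic acid there could still separate from chloro and nitro. Also open, on these data alone, is whether unsubstituted phenyl or a longer chain on the carbonyl carbon would sit nearer to compound 1 or to the aryl pair.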